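Pyrrolidine amide series: replacing the lactam ring

The source may report more compounds than this note shows. Statements on the series, on what has been measured and on what is new or still open speak of the compounds shown alone.

Measured so far:
- compound 1, `O=C1CC[C@@H](C(=O)N2CCC(NS(=O)(=O)c3cc(S(=O)(=O)c4ccccc4)ccc3C(F)(F)F)CC2)N1`: 240 nM
- compound 2, `CC(C)C(=O)N1CCC[C@H]1C(=O)N1CCC(NS(=O)(=O)c2cc(S(=O)(=O)c3ccccc3)ccc2C(F)(F)F)CC1`: 90 nM

The two compounds share the whole sulfonamide part of compound 1 and differ only in the ring attached to the carbonyl carbon. In a functional assay on U2OS cells for antagonist activity at proto-oncogene Wnt-3 (Homo sapiens), read by a luciferase reporter, with a stated time of 18 h (a higher number here means that more compound is needed for the effect, a lower number that less compound is needed), compound 1 gives 240 nM, the higher of the two numbers recorded; in this assay compound 2 gives 90 nM. Within the data shown here, the one measured step is a 2.7-fold lower number from compound 1 to compound 2 (0.43 log units; beyond the scatter).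

Compound 3, `CC(C)(C)CCN1CCC[C@H]1C(=O)N1CCC(NS(=O)(=O)c2cc(S(=O)(=O)c3ccccc3)ccc2C(F)(F)F)CC1`, is not yet measured. Against compound 1 the change is 1-(3,3-dimethylbutyl)pyrrolidin-2-yl in place of 5-oxopyrrolidin-2-yl on a carbonyl carbon.

Among the measured compounds shown here, only the step from compound 1 to compound 2 bears on this, since it alters the same ring at the same carbonyl carbon, and it was a modest step toward a lower number. The new group in compound 3 is not the same as that in compound 2, so the size is uncertain, but a step in the same direction is expected, of roughly the size seen from compound 1 to compound 2, which gives a 2.2-fold lower number from compound 1 to compound 3 (0.34 log units; beyond the scatter). For compound 3 the expected value in this assay is 110 nM, with a range from 35 nM to 330 nM.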

Compound 3, half-maximal effective concentration: 450 nM
Compound 3: the middle estimate sits 4.1-fold (0.61 log units) below what was measured, outside the stated range (above it).
By their numbers in this assay, from the lowest: compound 2; then compounds 1 and 3 (each within the scatter of the next).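

In this assay the outcome at this position depends on what the pyrrolidine nitrogen carries, not on the replacement of the lactam alone: there is a 5.0-fold higher number from compound 2 to compound 3 (0.70 log units; beyond the scatter) when 3,3-dimethylbutyl stands in place of isopropylcarbonyl on the amine nitrogen in the ring. The gain seen with compound 2 therefore does not extend to every 1-substituted pyrrolidin-2-yl group, and compound 3 goes against any such pattern. The other comparison gives a 1.9-fold higher number from compound 1 to compound 3 (0.27 log units; within the scatter) and stays within the scatter, so the 1-(3,3-dimethylbutyl)pyrrolidin-2-yl and 5-oxopyrrolidin-2-yl groups are not separated here, even though the entering group has more heavy atoms.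

Since compound 2 and compound 3 differ in both the carbonyl and the shape of the chain on that nitrogen, these compounds cannot show which of the two matters. From the compounds shown here alone, it remains open whether an acetyl group, a cyclopropylcarbonyl group, a plain isobutyl chain or an unsubstituted ring amine at that nitrogen would track with compound 2 or with compound 3. No measurement at hand bears on the reason for the difference between these groups.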